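From chloro to methyl on the shared core

A few compounds are considered here, and "the series" means these few. Any claim that something is new, unique, unknown or untested is made for them only; others in the source may bear on it.

Among the measured compounds shown here, in an ADME assay on MT4 cells (Homo sapiens) for cytotoxicity, read by spectrophotometry, with a stated time of 5 days (on this read-out lower numbers stand for higher toxicity in this test and higher numbers for lower toxicity in this test), two compounds have numbers so far. Compound 1 (`CCn1cc(C(=O)O)c(=O)c2cc(F)c(N3CCN(CN4C(=O)/C(=N\NC(=S)NO)c5cc(C)ccc54)CC3)cc21`) gives 327000 nM and compound 2 (`CCn1cc(C(=O)O)c(=O)c2cc(F)c(N3CCN(CN4C(=O)/C(=N\NC(=S)NOC)c5cc(Cl)ccc54)CC3)cc21`) gives 193000 nM in this test. These two values lie within the scatter of each other, so compound 2 stands level with compound 1 on the numbers at hand. Compound 3 (`CCn1cc(C(=O)O)c(=O)c2cc(F)c(N3CCN(CN4C(=O)/C(=N\NC(=S)NOC)c5cc(C)ccc54)CC3)cc21`) has not yet been measured. It differs from compound 2 by a single swap (methyl in place of chloro on an aromatic carbon), methyl in place of chloro on an aromatic carbon. For the measured compounds named here, no measured pair isolates this swap. Going by the values given here, the only guide in this assay is that compound 1 with 327000 nM and compound 2 with 193000 nM lie close together, so no change beyond the scatter is expected. The estimated step of a 1.2-fold higher number from compound 2 to compound 3 (0.09 log units; within the scatter) is small, points to a slightly higher number and stays within the scatter. For compound 3 the expected value is about 240000 nM (estimated range 120000 nM to 420000 nM).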

Compound 3, half-maximal cytotoxic concentration: 238000 nM
For compound 3 the middle estimate is 1.0-fold (0.00 log units) above the measured one, and the stated range covers the measured number.
By their numbers in this assay, from the lowest: compounds 2, 3 and 1 (each within the scatter of the next).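

In this assay the swap of chloro for methyl on an aromatic carbon now has a measured pair of its own, and it gives a 1.2-fold higher number from compound 2 to compound 3 (0.09 log units; within the scatter) on the shared core. Methyl in place of hydrogen on an oxygen, also seen here in a single change for the first time, gives a 1.4-fold lower number from compound 1 to compound 3 (0.14 log units; within the scatter) in the same test, so neither change moves the read-out beyond the scatter. Nothing given here explains either result.

The compounds shown leave open whether a trifluoromethyl or a methoxy group on that aromatic carbon would give a step beyond the scatter. They also leave open what an ethyl chain or a benzyl group on the oxygen would do in this assay.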